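The source may report more compounds than this note shows. Statements on the series, on what has been measured and on what is new or still open speak of the compounds shown alone.

Compound 2 `O=C(N1CCN(C(c2ccc3ccccc3c2)c2ccc3ccccc3c2)CC1)n1cccn1` gives 1800 nM in an assay on membranes from brain for binding affinity to Monoglyceride lipase (Mus musculus), read by fluorescence, with stated times of 1 h and 30 min (on this read-out lower numbers stand for stronger inhibition and higher numbers for weaker inhibition), and stands with the highest number of the two measured compounds. Among the compounds with values here, the only neighbour is compound 1 `Cc1cnn(C(=O)N2CCN(C(c3ccc4ccccc4c3)c3ccc4ccccc4c3)CC2)c1`, which gives 260 nM in this assay; the step of a 6.9-fold higher number from compound 1 to compound 2 (0.84 log units; beyond the scatter) shows that replacing the methyl on the five-membered aromatic ring with hydrogen weakened inhibition.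

Compound 3 `N#Cc1cnn(C(=O)N2CCN(C(c3ccc4ccccc4c3)c3ccc4ccccc4c3)CC2)c1` differs from compound 2 by cyano in place of hydrogen on an aromatic carbon. Within the data shown here, the one measured step that bears on this change is a 6.9-fold higher number from compound 1 to compound 2 (0.84 log units; beyond the scatter), in which a group on that same ring carbon was removed and the number rose; adding a cyano group at that carbon is expected to move the number back down by a step of similar order, a 4.5-fold lower number from compound 2 to compound 3 (0.65 log units; beyond the scatter). The estimate for compound 3 in this assay is therefore 400 nM, with a range from 100 nM to 1500 nM.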

Compound 3, half-maximal inhibitory concentration: 8 nM
Compound 3: the middle estimate sits 50-fold (1.70 log units) above what was measured; the whole stated range lies above it.
By their numbers in this assay, from the lowest: compound 3; then compound 1; then compound 2.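

In this assay, placing a cyano group on this ring carbon gives a 230-fold lower number from compound 2 to compound 3 (2.35 log units; beyond the scatter), so the position can shift inhibition much further than the methyl group alone had indicated. Cyano in place of methyl at the same carbon still gives a 33-fold lower number from compound 1 to compound 3 (1.51 log units; beyond the scatter), which shows that the outcome depends on which group sits there and not merely on the carbon being substituted. Nothing available here accounts for the advantage of cyano over methyl at this carbon.

The compounds shown leave open how other groups on this carbon would compare, such as a carboxylic acid, a primary amide, chlorine or a longer chain like cyanomethyl. They also leave open whether the 4-cyano-1H-pyrazol-1-yl group would give a similar gain on a different core.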